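This account rests on a few compounds, and the source may have more. Where it says the series, first, only, none or still open, it means among the compounds named here.

Measured so far in a functional assay on NCI-H2122 cells (Homo sapiens) for inhibition, read by microscopy, with a stated time of 10 days; on this read-out higher numbers stand for weaker inhibition and lower numbers for stronger inhibition:
compound 1 `Cc1nn(C)c2c1C(c1ccccc1)C(C#N)=C(N)O2` gives 9100 nM
compound 3 `Cc1nn(C)c2c1C(c1cc(F)cc(F)c1)C(C#N)=C(N)O2` gives 4200 nM

Compound 2 `Cn1nc(-c2ccccc2)c2c1OC(N)=C(C#N)C2c1ccccc1` reaches only a limit of this assay, > 10000 nM.

Compound 1 and compound 2 differ in one place (phenyl in place of methyl on an aromatic carbon), and this step is an at least 1.0-fold higher number from compound 1 to compound 2 (0.04 log units; that floor lies within the scatter), a floor set by the limit of > 10000 nM in this assay, at which 1 of the 3 values shown sits. Compound 3 holds the lowest of the two numbers; the difference between its core and the core of compound 1 is not broken down here. Compound 4 `Cn1nc(-c2ccccc2)c2c1OC(N)=C(C#N)C2c1cc(F)cc(F)c1` is not yet measured; it differs from compound 3 by phenyl in place of methyl on an aromatic carbon, the same change at the same place as the one already measured. For compound 4 the step is expected to be a 1.7-fold higher number from compound 3 to compound 4 (0.22 log units; within the scatter), because the earlier change gave an at least 1.0-fold higher number from compound 1 to compound 2 (0.04 log units; that floor lies within the scatter) and ended at the limit of > 10000 nM in this assay, at which 1 of the 3 values shown sits. Compound 4 is therefore estimated at 7000 nM, likely between 3000 nM and 20000 nM.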

Compound 4, half-maximal inhibitory concentration: 6600 nM
Compound 4: the middle estimate sits 1.1-fold (0.03 log units) above what was measured; the range from low to high includes it.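

In this assay, phenyl in place of methyl on the aromatic carbon gives a 1.6-fold higher number from compound 3 to compound 4 (0.20 log units; within the scatter), so on this core the change makes no clear difference. In this assay, compound 2 reaches only a limit, > 10000 nM. The series therefore does not show that the change has the same size on both cores, only that no difference between them can be read: the same change on two cores in this assay, an at least 1.0-fold higher number (0.04 log units; that floor lies within the scatter) from compound 1 to compound 2 and a 1.6-fold higher number (0.20 log units; within the scatter) from compound 3 to compound 4; the limit leaves it open whether they differ

Placing 3,5-difluorophenyl in place of phenyl on the saturated ring carbon gives an at least 1.5-fold lower number from compound 2 to compound 4 (0.18 log units; that floor lies within the scatter), and as this step starts from that limit, its true size stays open. Also open, from the compounds shown here alone, is how an ethyl group, a longer chain or an amine on the same aromatic carbon would read.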